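This account rests on a few compounds, and the source may have more. Where it says the series, first, only, none or still open, it means among the compounds named here.

Measured so far in an assay on SHEP1 cells for displacement of a labelled ligand from Neuronal acetylcholine receptor; alpha4/beta2 (Homo sapiens), read by scintillation counting, with a stated time of 2 h; on this read-out lower numbers stand for stronger inhibition and higher numbers for weaker inhibition:
compound 1 `C[C@@H]1C[C@H]1C(=O)N1CC2CNCC2C1` gives 4 nM
compound 2 `CCC(=O)N1CC2CNCC2C1` gives 12 nM

For the measured compounds named here, compound 1 holds the lowest number of the two measured in this assay; its nearest neighbour is compound 2, reached by a 3.0-fold higher number from compound 1 to compound 2 (0.48 log units; beyond the scatter), the only step so far at the carbonyl carbon of the shared core.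

Compound 3 `COC(=O)N1CC2CNCC2C1` is not yet measured in this assay. It differs from compound 1 in one place: methoxy in place of 2-methylcyclopropyl on a carbonyl carbon. Going by the values given here, the one measured step that bears on this is a 3.0-fold higher number from compound 1 to compound 2 (0.48 log units; beyond the scatter), where the same 2-methylcyclopropyl group gave way to ethyl and the number rose modestly. Methoxy is a further departure: it is smaller than ethyl and brings an oxygen in place of carbon, and no measured pair shows such a swap. The expectation is therefore a rise in this assay rather than a fall, plausibly somewhat larger than the step to compound 2, with wide uncertainty.

For compound 3 the expected step is a 6.3-fold higher number from compound 1 to compound 3 (0.80 log units; beyond the scatter). Compound 3 is thus estimated at 25 nM in this assay, with a likely range of 8 nM to 80 nM.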

Compound 3, inhibition constant: 23 nM
For compound 3 the middle estimate is 1.1-fold (0.04 log units) above the measured one; measured number inside the range.
By their numbers in this assay, from the lowest: compound 1; then compounds 2 and 3 (each within the scatter of the next).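

In this assay, replacing 2-methylcyclopropyl on the carbonyl carbon with methoxy gives a 5.8-fold higher number from compound 1 to compound 3 (0.76 log units; beyond the scatter), so a second group without a ring also separates from compound 1 beyond the scatter, this time with an oxygen attached to the carbonyl carbon. The exchange of ethyl for methoxy gives a 1.9-fold higher number from compound 2 to compound 3 (0.28 log units; within the scatter), which shows that at this place, among the groups shown, ethyl and methoxy are not told apart in this read-out, and that the change from carbon to oxygen on the carbonyl carbon does not by itself produce a step beyond the scatter. No supporting data are available to explain either step.

The compounds shown leave open whether the lower number of compound 1 goes with the three-membered ring, its methyl substituent or its defined stereocentres; plain cyclopropyl and a longer chain such as butyl on the same carbonyl carbon would begin to separate these. They also leave open how an amine at this place would read against methoxy and ethyl, and whether an ether chain longer than methoxy would stay within the scatter of compound 3.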